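Shrinking a Small Ring on a Shared Core

This account rests on a few compounds, and the source may have more. Where it says the series, first, only, none or still open, it means among the compounds named here.

In an assay on membranes from HEK293 cells for displacement of a labelled ligand from Type-2 angiotensin II receptor (Homo sapiens), read by radioligand binding (on this read-out higher numbers stand for weaker inhibition and lower numbers for stronger inhibition), compound 1 `CCCCOC(=O)NS(=O)(=O)c1ccc(CCC)cc1-c1ccc(Cn2c(-c3nccs3)nc3ccccc32)cc1` gives 5.1 nM, compound 2 `CCCCOC(=O)NS(=O)(=O)c1ccc(CCC)cc1-c1ccc(Cn2c(CCCC)nc3ccccc32)cc1` gives 9.2 nM, and compound 3 `CCCCOC(=O)NS(=O)(=O)c1ccc(CCC)cc1-c1ccc(Cn2c(C3CCC3)nc3ccccc32)cc1` gives 12 nM, the highest of the three numbers. The step of a 1.3-fold higher number from compound 2 to compound 3 (0.12 log units; within the scatter) lies within the scatter, while a 2.4-fold higher number from compound 1 to compound 3 (0.37 log units; beyond the scatter) is modest. Compound 4 `CCCCOC(=O)NS(=O)(=O)c1ccc(CCC)cc1-c1ccc(Cn2c(C3CC3)nc3ccccc32)cc1` differs from compound 3 only by cyclopropyl in place of cyclobutyl on an aromatic carbon. For the measured compounds named here, no measured pair covers a cyclobutyl-to-cyclopropyl exchange; the nearest guide is the small change seen when butyl gave way to cyclobutyl. Compound 4 is therefore expected to show no step beyond the scatter because a 1.3-fold higher number from compound 2 to compound 3 (0.12 log units; within the scatter) was itself small, so no change at the digits printed from compound 3 to compound 4 (within the scatter) is anticipated. The estimate for compound 4 in this assay is 12 nM, with a range from 6 nM to 25 nM.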

Compound 4, inhibition constant: 31 nM
Compound 4: middle estimate off by 2.6-fold (0.41 log units), on the low side, and the stated range ends below it.
By their numbers in this assay, from the lowest: compounds 1, 2 and 3 (each within the scatter of the next, the first and the last beyond it); then compound 4.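

In this assay this position proves sensitive to a single ring carbon: cyclopropyl in place of cyclobutyl gives a 2.6-fold higher number from compound 3 to compound 4 (0.41 log units; beyond the scatter), although a 1.3-fold higher number from compound 2 to compound 3 (0.12 log units; within the scatter) had shown no step beyond the scatter. The gap also stands against the open chain, with a 3.4-fold higher number from compound 2 to compound 4 (0.53 log units; beyond the scatter), and is widest against the thiazole, with a 6.1-fold higher number from compound 1 to compound 4 (0.78 log units; beyond the scatter). Compound 4 is thus the weakest of the four, and its steps to all three others lie beyond the scatter.

Going by these compounds, whether a cyclopentyl or a methyl group on this carbon would sit with compound 3 or with compound 4 remains open. Nothing available here explains the loss on going to cyclopropyl.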